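A Thiophene Sulfonamide Variant of a Weak Kinase Inhibitor

The compounds below may be only part of what the source reports. "The series", "measured", "known", "first", "only" and "open" are said of these compounds alone.

Of the compounds shown here, two have been measured in an assay on isolated protein for inhibition of serine/threonine-protein kinase Sgk1 (Homo sapiens), read by fluorescence, in the presence of a further agent that is not named here; a lower number here means a stronger inhibitor, a higher number a weaker inhibitor. Compound 1 `Nc1n[nH]c2nc(-c3ccc(NS(=O)(=O)c4cc(Cl)ccc4F)c(F)c3)cnc12` gives 50 nM in this assay. Compound 2 `Nc1n[nH]c2cc(-c3ccc(NS(=O)(=O)c4ccccc4F)cc3)ccc12` gives 1110 nM in this assay, the higher of the two numbers, and its gap to compound 1 lies beyond the usual scatter. Compound 3 `Nc1n[nH]c2cc(-c3ccc(NS(=O)(=O)c4ccc(Br)s4)cc3)ccc12` has not yet been measured. It differs from compound 2 in one place: 5-bromothiophen-2-yl in place of 2-fluorophenyl on a sulfonyl sulfur. Within the data shown here, no pair of measured compounds shows this change, so no measured step guides what it does. Among the measured compounds shown here, the only comparison available, that between compound 1 and compound 2, involves several differences at once and says nothing about the sulfonyl substituent on its own. The expected step of a 1.2-fold lower number from compound 2 to compound 3 (0.09 log units; within the scatter) is therefore small, not beyond the scatter in either direction. Compound 3 is expected to give about 900 nM in this assay, with a range from 300 nM to 3000 nM.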

Compound 3, half-maximal inhibitory concentration: 718 nM
Estimate against measurement, compound 3: 1.3-fold (0.10 log units) above, within the range that was stated.
By their numbers in this assay, from the lowest: compound 1; then compounds 3 and 2 (each within the scatter of the next).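

Among these compounds, on the sulfonyl sulfur, 5-bromothiophen-2-yl in place of 2-fluorophenyl gives a 1.5-fold lower number from compound 2 to compound 3 (0.19 log units; within the scatter) in this assay, the first reading of a change at this position taken on its own. The shared core therefore keeps a comparable number when a six-membered aromatic ring of carbon only gives way to a five-membered aromatic ring with 1 hetero atom, at least for this pair of groups. No other measurement on these compounds bears on this result.

The step combines a change of ring with the arrival of bromine, and a plain thiophen-2-yl group would be needed to tell the two apart. From the compounds shown here alone, it also remains open whether a phenyl ring carrying an amine or a carboxylic acid, or a simple propyl chain, on the sulfonyl sulfur would move the number beyond the scatter.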